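Working notes on a cyanoguanidine series: compounds 1, 2 and 3

The source may report more compounds than this note shows. Statements on the series, on what has been measured and on what is new or still open speak of the compounds shown alone.

Measured so far:
compound 1, `CCC/N=C(/NC#N)NCCCCCn1nc(-c2ccccc2)ccc1=O` — > 100 mg/kg
compound 2, `CN/C(=N/CCCCn1nc(-c2ccc(OC)cc2)ccc1=O)NC#N` — > 100 mg/kg

In a functional assay on the whole organism (stomach) with Rattus norvegicus as the target (a lower number here means that less compound is needed, a higher number that more compound is needed for the effect), compound 1 gives > 100 mg/kg, which is a limit of the assay and not a number. Compound 2 gives > 100 mg/kg in this assay, again a limit rather than a number. For the measured compounds named here, compound 1 thus stands at the limit of > 100 mg/kg in this assay, at which 2 of the 2 values shown sit; no step between measured compounds can be stated from these two values.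

Compound 3, `CN(C)/C(=N/CCCCCCn1nc(-c2ccccc2)ccc1=O)NC#N`, has not been measured in this assay. Set against compound 1 the change is a group of 9 heavy atoms (5 carbon, 4 nitrogen; no ring) in place of a group of 9 heavy atoms (5 carbon, 4 nitrogen; no ring), on a saturated chain carbon, five bonds along the chain from an aromatic nitrogen.

Going by the values given here, with compound 1 sitting at a limit, no step in this assay beyond the scatter is expected in either direction, and the most likely outcome for compound 3 is once more a limit. For compound 3 the estimated value is 150 mg/kg, with a range from 40 mg/kg to 600 mg/kg, an expected step that the limit leaves unreadable from compound 1 to compound 3.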

Compound 3, dose for half-maximal effect: 93.1 mg/kg
The estimate for compound 3 lay 1.6-fold (0.21 log units) above the measured number; low and high end bracket the measured number.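

In this assay, for the compounds shown here, compound 3 gives 93.1 mg/kg, the first actual number rather than a limit. Compound 1 gives > 100 mg/kg, which is a limit of the assay and not a number. The change on the saturated chain carbon, five bonds along the chain from an aromatic nitrogen, which replaces a group with 2 hydrogen-bond donors by one with 1, can therefore be stated only as a floor, an at least 1.0-fold lower number from compound 1 to compound 3 (0.03 log units; that floor lies within the scatter), and no real difference can be claimed from it.

Most of the series still sits at a single limit: the limit of > 100 mg/kg in this assay, at which 2 of the 3 values shown sit. Open, from the compounds shown here alone, is whether a longer chain, or an amine or a carboxylic acid at the chain end in place of the cyanoguanidine, would give a number clearly beyond the scatter.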